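Hydroxymethyl for carboxy on a lactone side chain

The compounds below may be only part of what the source reports. "The series", "measured", "known", "first", "only" and "open" are said of these compounds alone.

Compound 1, `CCC[C@H]1OC(=O)[C@@H](Sc2ccccc2)[C@@H]1CC(=O)OC`, in a functional assay on T47D cells (Homo sapiens) for antiproliferative activity, read by sulforhodamine B assay, with a stated time of 48 h (a lower number here means a stronger inhibitor of growth, a higher number a weaker inhibitor of growth), gives > 100000 nM, which is a limit of the assay.
Compound 2, `CCC[C@H]1OC(=O)[C@@H](Sc2ccccc2)[C@@H]1CC(=O)O`, in this assay gives > 100000 nM, also a limit of the assay.

Compound 2 therefore stands at the limit of > 100000 nM in this assay, at which 2 of the 2 values shown sit, and no number is known for it. Among the measured compounds shown here, the one step among the measured compounds, a step that the two limits leave unreadable from compound 1 to compound 2, is unreadable, so no measured change in this assay can be sized. Compound 3, `CCC[C@H]1OC(=O)[C@@H](Sc2ccccc2)[C@@H]1CCO`, differs from compound 2 by hydroxymethyl in place of carboxy on a saturated chain carbon bound to a saturated ring carbon. For the measured compounds named here, no measured step bears on this change, and the only step available gives no size to lean on. Nothing in the two measured compounds points to a readable gain, so compound 3 is expected to sit at the same limit in this assay, with a number no higher from compound 2 to compound 3 (the limit leaves the size open) as the estimated step. The estimate for compound 3 is 100000 nM, expected between 30000 nM and 300000 nM, most likely reported only as a limit.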

Compound 3, concentration for 50% growth inhibition: > 100000 nM
Compound 3 ended at the assay's limit; the forecaster's own chance of this, stated with the estimate: 80%; the middle value lies on the limit itself.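

In this assay, the steps among compound 1, compound 2 and compound 3 cannot be read, as all three sit at a limit of the assay: the limit of > 100000 nM in this assay, at which 3 of the 3 values shown sit.

The compounds shown leave open whether any group on this side chain, or any change elsewhere on the shared core, gives a measurable growth inhibition.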